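A few compounds are considered here, and "the series" means these few. Any claim that something is new, unique, unknown or untested is made for them only; others in the source may bear on it.

Measured so far:
Compound 1, `COC(=O)C1=C(C)N=C(C)/C(=C(\O)OC)C1c1ccccc1Cl`, in a functional assay (muscle tissue) with Cavia porcellus as the target (a higher number here means that more compound is needed for the effect, a lower number that less compound is needed), gives 2.19 nM.
Compound 2, `COC(=O)C1=C(C)N=C(C)/C(=C(\O)OC)C1c1ccccc1N`, in this assay gives 39800 nM.
Compound 3, `COC(=O)C1=C(C)N=C(C)/C(=C(\O)OC)C1c1cccc(C(F)(F)F)c1`, in this assay gives 74.1 nM.

Compound 2 stands at the highest number of the three, so it needs the most compound for the effect. Its nearest neighbour is compound 3, whose number is far lower; compound 1 lies even further below. Compound 4, `COC(=O)C1=C(C)N=C(C)/C(=C(\O)OC)C1c1cccc(C#N)c1`, has not yet been measured. The change from compound 2 to compound 4 is 3-cyanophenyl in place of 2-aminophenyl on a saturated ring carbon.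

Within the data shown here, only one measured step touches the same place on the shared core: an 18000-fold higher number from compound 1 to compound 2 (4.26 log units; beyond the scatter). That step shows that exchanging the group on this saturated ring carbon can move the number enormously. Compound 3, which carries a 3-trifluoromethylphenyl at the same place, sits at a much lower number than compound 2, and compound 1 with a 2-chlorophenyl sits lower still. Since compound 4 carries a 3-cyanophenyl rather than the 2-aminophenyl, a large step downward is expected, of roughly a 660-fold lower number from compound 2 to compound 4 (2.82 log units; beyond the scatter). For compound 4 the expected value is 60 nM, estimated between 8 nM and 500 nM.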

Compound 4, half-maximal effective concentration: 34.7 nM
For compound 4 the middle estimate is 1.7-fold (0.24 log units) above the measured one; the range from low to high includes it.
By their numbers in this assay, from the lowest: compound 1; then compound 4; then compound 3; then compound 2.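

In this assay, a 1100-fold lower number from compound 2 to compound 4 (3.06 log units; beyond the scatter) shows that a high number is not general for groups on this saturated ring carbon: replacing 2-aminophenyl with 3-cyanophenyl brings the number back down by a very large margin. The step from 3-trifluoromethylphenyl to 3-cyanophenyl gives a 2.1-fold lower number from compound 3 to compound 4 (0.33 log units; beyond the scatter), which is beyond the scatter but modest, so these two groups stay much closer to each other than either does to the 2-aminophenyl of compound 2. Even so, 3-cyanophenyl does not match 2-chlorophenyl, as a 16-fold higher number from compound 1 to compound 4 (1.20 log units; beyond the scatter) is still a large step, and compound 1 keeps the lowest number of the four.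

Nothing available here explains any of these steps. The step from 2-aminophenyl to 3-cyanophenyl changes both the group on the phenyl ring and where it sits, so the two effects cannot be separated, and open questions remain as to how 3-aminophenyl, 2-cyanophenyl or unsubstituted phenyl would compare on the shared core.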